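Notes on the aryl swap from compound 1

The source may hold more compounds than are shown below. What is called first, only, known or untested is meant among the compounds shown, and "the series" means these compounds.

- compound 1 `Cc1ccc(Nc2ncc(C(F)(F)F)c(N3Cc4cccc(N(C)S(C)(=O)=O)c4C3)n2)c(Cl)c1` gives > 30000 nM (a limit, not a number)
- compound 2 `CN(c1cccc2c1CN(c1nc(Nc3ccc(Nc4ccccc4)cc3)ncc1C(F)(F)F)C2)S(C)(=O)=O` gives 6200 nM

Compound 1 gives no number in a functional assay on A549 cells (Homo sapiens) for antiproliferative activity, read by spectrophotometry, with a stated time of 2 days (on this read-out higher numbers stand for weaker inhibition of growth and lower numbers for stronger inhibition of growth), only (the limit of > 30000 nM in this assay, at which 1 of the 2 values shown sits).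

Compound 3 `Cc1cc(C)cc(Nc2ncc(C(F)(F)F)c(N3Cc4cccc(N(C)S(C)(=O)=O)c4C3)n2)c1` carries 3,5-dimethylphenyl in place of 2-chloro-4-methylphenyl on a nitrogen on an aromatic ring. For the measured compounds named here, no measured step covers this change, so the expectation is loose. Compound 2 shares the core and gives 6200 nM, so a measurable number remains possible for compound 3. A small step towards stronger inhibition is expected: an at least 1.5-fold lower number from compound 1 to compound 3 (0.17 log units; that floor lies within the scatter). The estimate for compound 3 is 20000 nM, with an expected range of 8000 nM to 50000 nM.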

Compound 3, concentration for 50% growth inhibition: > 30000 nM
Compound 3: a limit, no number; the forecaster's own chance of this, stated with the estimate: 45%; at least 1.5-fold (0.17 log units) between middle value and limit.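

Compound 1 and compound 3 both stand at a limit, not a number, so no step between them can be read: the limit of > 30000 nM in this assay, at which 2 of the 3 values shown sit.

The compounds shown leave open whether 2-chloro-4-methylphenyl and 3,5-dimethylphenyl differ at all in inhibition of growth.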